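Shortening the ester chain of a cytosine nucleoside

A few compounds are considered here, and "the series" means these few. Any claim that something is new, unique, unknown or untested is made for them only; others in the source may bear on it.

The study looks at cytotoxicity in a functional assay on HeLa cells (Homo sapiens) for cytotoxicity, read by cell counting, with a stated time of 48 h (on this read-out higher numbers stand for an effect only at larger amounts of compound and lower numbers for an effect already at smaller amounts), across a small set of esters of one cytosine nucleoside core. Compound 1 `CCCCCCCCCCCCCCCCCCCCCC(=O)O[C@H]1[C@H](O)[C@H](n2ccc(N)nc2=O)O[C@@H]1CO` carries a single long ester and gives 1.1 ug/mL in this assay. Compound 2 `CCCCCCCCCCCCCCCCCCCCCC(=O)OC[C@H]1O[C@@H](n2ccc(N)nc2=O)[C@@H](O)[C@@H]1OC(=O)CCCCCCCCCCCCCCCCCCCCC` carries two such long esters; for compound 2 this assay reports only a limit, > 10 ug/mL, which is the limit of > 10 ug/mL in this assay, at which 1 of the 3 values shown sits. Compound 3 `CCCCCC(=O)OC[C@H]1O[C@@H](n2ccc(N)nc2=O)[C@@H](O)[C@@H]1OC(=O)CCCCC` carries two short esters and gives 0.07 ug/mL in this assay. Among the two plain numbers, compound 1 stands highest, and its number lies well beyond the scatter from that of compound 3.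

Compound 4 `CCCCCCCCCCCC(=O)O[C@H]1[C@H](O)[C@H](n2ccc(N)nc2=O)O[C@@H]1CO`, not yet measured in this assay, differs from compound 1 in one place: hydrogen in place of decyl on a saturated chain carbon, ten or more bonds along the chain from a carbonyl carbon. The shorter esters of compound 3 go with the lowest number seen, so the account expects the step from compound 1 to compound 4 to lower the number: a 3.1-fold lower number from compound 1 to compound 4 (0.50 log units; beyond the scatter). On that reading, compound 4 is estimated at 0.35 ug/mL in this assay, within the range 0.1 ug/mL to 1.5 ug/mL.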

Compound 4, concentration for half-maximal effect: 0.08 ug/mL
Beside the measured number, compound 4's estimate is 4.4-fold (0.64 log units) above it; measured number outside the range, below it.
By their numbers in this assay, from the lowest: compounds 3 and 4 (each within the scatter of the next); then compound 1. At a limit, above all of these: compound 2.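

For the compounds shown here, this is the first change in one place alone: with hydrogen in place of decyl on a saturated chain carbon, ten or more bonds along the chain from a carbonyl carbon, this assay shows a 14-fold lower number from compound 1 to compound 4 (1.14 log units; beyond the scatter), a large step. The earlier compounds shown here differed from one another in more than one place, so the outer part of this single ester chain could not be read by itself; here the number is seen to depend strongly on it. Nothing measured among these compounds gives a cause for this step.

The compounds shown leave open how the number runs at chain lengths between those of this pair. They also leave open whether a chain ending in an amine or a carboxylic acid would give a similar number at this position.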